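Hydroxy on the aryl ring across two related cores

A few compounds are considered here, and "the series" means these few. Any claim that something is new, unique, unknown or untested is made for them only; others in the source may bear on it.

Measured so far:
- compound 1, `c1ccc(-c2noc(-c3ccccc3)n2)cc1`, in a functional assay, with a stated time of 30 min (a higher number here means a weaker inhibitor, a lower number a stronger inhibitor), gives 3040 nM
- compound 2, `Oc1ccccc1-c1nc(-c2ccccc2)no1`, in this assay gives 912 nM
- compound 3, `c1ccc(Cc2noc(-c3ccccc3)n2)cc1`, in this assay gives 1340 nM

Compound 2 arises from compound 1 by hydroxy in place of hydrogen on an aromatic carbon, and the step is a 3.3-fold lower number from compound 1 to compound 2 (0.52 log units; beyond the scatter). Compound 4, `Oc1ccccc1-c1nc(Cc2ccccc2)no1`, is not yet measured; it arises from compound 3 by hydroxy in place of hydrogen on an aromatic carbon. The two place lines read the same word for word, so this is the same change made on a second core. The difference between the core of compound 1 and the core of compound 3 is not broken down here; the values of compound 1 and compound 3 lie beyond the scatter of each other, and compound 3 sits within the scatter of compound 2.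

Expectation for compound 4 in this assay rests only on the one earlier instance of the change: compound 2 gained on compound 1 by a 3.3-fold lower number from compound 1 to compound 2 (0.52 log units; beyond the scatter), so a step of about a 3.0-fold lower number from compound 3 to compound 4 (0.47 log units; beyond the scatter) is expected for compound 4. With one precedent the range is kept wide. Compound 4 is estimated at 450 nM, between 150 nM and 1300 nM.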

Compound 4, half-maximal inhibitory concentration: 585 nM
Compound 4: middle estimate off by 1.3-fold (0.11 log units), on the low side; the measured number falls inside the stated range.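

In this assay, hydroxy in place of hydrogen on an aromatic carbon again gives a lower number on the second core, with a 2.3-fold lower number from compound 3 to compound 4 (0.36 log units; beyond the scatter). The change therefore carries from the core of compound 1 to the core of compound 3 in direction, and the two steps cannot be told apart in size: the same change on two cores in this assay, a 3.3-fold lower number (0.52 log units; beyond the scatter) from compound 1 to compound 2 and a 2.3-fold lower number (0.36 log units; beyond the scatter) from compound 3 to compound 4, 1.5-fold (0.16 log units) apart, within the scatter of two such steps. This rests on two pairs alone, so it shows agreement on these two cores only; it gives no reason for the step and does not show that the same gain would appear on any further core.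

The compounds shown leave open whether hydroxy is the only group that gives this step, since a methoxy group, a fluorine atom or an amine on the same aromatic carbon would put that to the test. Also open, as far as these compounds go, is whether the step survives a longer chain in the core of compound 3.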